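Swapping methoxy for chloro on the pendant phenyl ring

The compounds below may be only part of what the source reports. "The series", "measured", "known", "first", "only" and "open" are said of these compounds alone.

Measured compounds:
compound 1 `O=C1N=C(N2N=C(c3ccccc3)CC2c2ccccc2O)S/C1=C1/C(=O)Nc2ccccc21`: 4350 nM
compound 2 `COc1ccc(C2CC(c3ccccc3)=NN2C2=NC(=O)/C(=C3\C(=O)Nc4ccccc43)S2)cc1`: 3350 nM
compound 3 `COc1ccc(C2=NN(C3=NC(=O)/C(=C4\C(=O)Nc5ccccc54)S3)C(c3ccc(OC)cc3)C2)cc1`: 100000 nM

In a functional assay on cells (Cancer cell lines, Homo sapiens) for cytotoxicity, read by sulforhodamine B assay, with a stated time of 48 h (on this read-out lower numbers stand for stronger inhibition of growth and higher numbers for weaker inhibition of growth), compound 2 gives the lowest of the three numbers. Its nearest neighbour is compound 1, by a 1.3-fold lower number from compound 1 to compound 2 (0.11 log units; within the scatter); compound 3 lies much further off, by a 30-fold higher number from compound 2 to compound 3 (1.47 log units; beyond the scatter). Compound 4 `O=C1N=C(N2N=C(c3ccccc3)CC2c2ccc(Cl)cc2)S/C1=C1/C(=O)Nc2ccccc21` differs from compound 2 by chloro in place of methoxy on an aromatic carbon. The change sits on the same saturated-ring phenyl that was varied from compound 1 to compound 2, where even exchanging 2-hydroxyphenyl for 4-methoxyphenyl moved this assay only within the scatter. The large step from compound 2 to compound 3 concerns a different ring and does not bear directly on this exchange. For compound 4 a step of a 1.0-fold higher number from compound 2 to compound 4 (0.02 log units; within the scatter) is therefore expected, none beyond the scatter. Compound 4 is estimated at 3500 nM, ranging from 1500 nM to 9000 nM.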

Compound 4, concentration for total growth inhibition: 850 nM
Beside the measured number, compound 4's estimate is 4.1-fold (0.61 log units) above it; the whole stated range lies above it.
By their numbers in this assay, from the lowest: compound 4; then compounds 2 and 1 (each within the scatter of the next); then compound 3.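

Until now, changing the group on this phenyl had moved this assay only within the scatter, but 4-chlorophenyl gives a 3.9-fold lower number from compound 2 to compound 4 (0.60 log units; beyond the scatter) and a 5.1-fold lower number from compound 1 to compound 4 (0.71 log units; beyond the scatter) with both steps beyond the scatter. This position can therefore change the growth-inhibition number by a modest amount, and the change from methoxy to chloro is enough to do so. Nothing measured here explains this result. The compounds shown leave open whether fluoro, bromo or trifluoromethyl in place of chloro would give a lower number still. They also do not show how an amine or a carboxylic acid would behave there.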